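Shortening the side chain of an endothelin receptor ligand

The source may report more compounds than this note shows. Statements on the series, on what has been measured and on what is new or still open speak of the compounds shown alone.

Measured so far:
Compound 1, `Cc1onc(NS(=O)(=O)c2ccc(N)cc2)c1I`, gives > 1000000 nM in an assay on COS-7 cells for displacement of a labelled ligand from Endothelin receptor type B (Sus scrofa) (a higher number here means a weaker inhibitor, a lower number a stronger inhibitor), which is a limit of the assay rather than a number.
Compound 2, `COc1cccc(Sc2c(NS(=O)(=O)c3ccc(C(C)(C)C)cc3)noc2CCCCC=O)c1`, gives 20 nM in this assay.

For the measured compounds named here, compound 2 provides the only actual number on record here; the other entry for compound 1 is a limit, as the line the limit of > 1000000 nM in this assay, at which 1 of the 2 values shown sits, records. Compound 2 is therefore the only fixed point from which an expectation can be built.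

Compound 3, `COc1cccc(Sc2c(NS(=O)(=O)c3ccc(C(C)(C)C)cc3)noc2CCO)c1`, differs from compound 2 in one place: hydroxy in place of 2-formylethyl on a saturated chain carbon, two bonds along the chain from an aromatic carbon. The long chain ending in an aldehyde is cut back to a short chain ending in an alcohol.

Going by the values given here, no pair of measured compounds shows such a change. The size of the step is uncertain. A moderate loss in this assay is expected, with a real chance that the result stays within the scatter of compound 2. Compound 3 is estimated at 60 nM, with a range of 12 nM to 300 nM, which corresponds to an expected step of a 3.0-fold higher number from compound 2 to compound 3 (0.48 log units; beyond the scatter).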

Compound 3, half-maximal inhibitory concentration: 430 nM
Estimate against measurement, compound 3: 7.2-fold (0.86 log units) below; measured number outside the range, above it.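

For the compounds shown here, compound 2 and compound 3 form the first pair here that differ in one place, so the side chain can now be judged directly: in this assay, putting hydroxy in place of 2-formylethyl, which cuts the long chain ending in an aldehyde back to a short chain ending in an alcohol, brings a 22-fold higher number from compound 2 to compound 3 (1.33 log units; beyond the scatter). This large step shows that the binding measured here is sensitive to what this chain carries, although compound 3, at 430 nM, still gives a real number and not a limit, so the long chain ending in an aldehyde is not needed for a measurable result. Going by these compounds alone, nothing measured so far gives a reason for the size of this step.

On these data alone, the shorter chain and the new alcohol end arrive together in this single change, so their separate shares in the step remain unknown, and a longer chain ending in an alcohol would help to pull them apart. Also open, as far as these compounds go, is how a short chain ending in an amine or a carboxylic acid would behave in this assay.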